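The source may report more compounds than this note shows. Statements on the series, on what has been measured and on what is new or still open speak of the compounds shown alone.

Measured in a functional assay, read by fluorescence and spectrophotometry, with a stated time of 1 h; a higher number here means that more compound is needed for the effect, a lower number that less compound is needed:
- compound 1 `C=CCCCCCCCS(=O)(=O)/C=C/c1ccc(O)c(O)c1`: 6900 nM
- compound 2 `O=S(=O)(/C=C/c1ccc(O)c(O)c1)CC1CCC1`: 8800 nM

With only these two numbers, compound 2 at 8800 nM cannot be told apart from compound 1 at 6900 nM, since the pair lies within the usual scatter of repeated measurements. The next compound, compound 3 `O=S(=O)(/C=C/c1ccc(O)c(O)c1)CCC1CCCCC1`, keeps the shared core and has cyclohexylmethyl in place of cyclobutyl on a saturated chain carbon bound to a sulfonyl sulfur. Among the compounds with values here, no measured step shows what this swap does. However, compound 1 and compound 2 carry quite different groups in this place and still give values within the scatter, so a large change in this assay is not expected. The estimated change, no larger than the scatter, is a 1.5-fold lower number from compound 2 to compound 3 (0.17 log units; within the scatter). The expected value for compound 3 is 6000 nM, with an estimated range of 2500 nM to 15000 nM.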

Compound 3, half-maximal effective concentration: 9800 nM
Compound 3: middle estimate off by 1.6-fold (0.21 log units), on the low side, within the range that was stated.
By their numbers in this assay, from the lowest: compounds 1, 2 and 3 (each within the scatter of the next).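

In this assay, placing cyclohexylmethyl in place of cyclobutyl on a saturated chain carbon bound to a sulfonyl sulfur gives a 1.1-fold higher number from compound 2 to compound 3 (0.05 log units; within the scatter), so adding carbon atoms to the ring-bearing group makes no readable difference here. The comparison with the open chain agrees: cyclohexyl in place of hept-6-en-1-yl on a saturated chain carbon, two bonds along the chain from a sulfonyl sulfur, gives a 1.4-fold higher number from compound 1 to compound 3 (0.15 log units; within the scatter), so the ring and the open chain cannot be told apart either. Nothing available explains why these three groups cannot be separated.

All three groups contain only carbon and hydrogen, which leaves open whether an amine or a carboxylic acid at this position would also give a similar number. A group as small as methyl also remains an open case.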